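The source may hold more compounds than are shown below. What is called first, only, known or untested is meant among the compounds shown, and "the series" means these compounds.

Three compounds share the core of compound 3 `N#CC1CN1C(N)=O`. In a functional assay on A549 cells (Homo sapiens) for inhibition (on this read-out higher numbers stand for weaker inhibition and lower numbers for stronger inhibition), compound 1 `CCCCNC(=O)N1CC1C#N` gives 18000 nM. In this assay compound 2 `N#CC1CN1C(=O)Nc1ccc(F)cc1` gives 6200 nM. Compound 3 itself is known only through a limit of this assay: it gives > 280000 nM. This is the limit of > 280000 nM in this assay, at which 1 of the 3 values shown sits. On the numbers shown, compound 3 thus stands apart from compound 1 by the step of an at least 15-fold higher number from compound 1 to compound 3 (1.19 log units; beyond the scatter), whose exact size is not known past that limit; against compound 2 no step is given, and only the two values themselves can be set side by side.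

Compound 4 `CNC(=O)N1CC1C#N` differs from compound 3 by methyl in place of hydrogen on an amide-type nitrogen. Among the measured compounds shown here, the one measured step that bears on this change is an at least 15-fold higher number from compound 1 to compound 3 (1.19 log units; beyond the scatter), in which butyl in place of hydrogen on the same amide-type nitrogen made the difference. Compound 4 carries methyl rather than the butyl of compound 1, and the expected step runs in the direction opposite to the step from compound 1 to compound 3, but of a size not known to match it. For compound 4 a lower number in this assay is expected, by an estimated step of an at least 2.8-fold lower number from compound 3 to compound 4 (0.44 log units; beyond the scatter). The estimate for compound 4 is 100000 nM, expected within a range from 25000 nM to 400000 nM.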

Compound 4, half-maximal inhibitory concentration: 22000 nM
The estimate for compound 4 lay 4.5-fold (0.66 log units) above the measured number; the whole stated range lies above it.
By their numbers in this assay, from the lowest: compound 2; then compounds 1 and 4 (each within the scatter of the next). At a limit, above all of these: compound 3.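

In this assay, methyl in place of hydrogen on the amide-type nitrogen is enough on its own to give an at least 12-fold lower number from compound 3 to compound 4 (1.10 log units; beyond the scatter), so the large step seen earlier with butyl does not require a chain of that length. Beyond methyl, the chain makes no difference that can be told apart from the scatter: hydrogen in place of propyl on a saturated chain carbon bound to an amide-type nitrogen gives a 1.2-fold higher number from compound 1 to compound 4 (0.09 log units; within the scatter), and methyl and butyl thus sit at one level on this nitrogen. How far the change from hydrogen to methyl really reaches stays unknown, since compound 3 is known only through a limit of the assay: the limit of > 280000 nM in this assay, at which 1 of the 4 values shown sits.

The compounds shown leave open whether this level holds across the chains in between, such as ethyl or propyl, and for a longer chain such as hexyl. They also leave open what a plain phenyl, or a chain ending in an amine or a carboxylic acid, would give on this nitrogen.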